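From a Nitro-Bearing Aryl Ring to a Small Furan

A few compounds are considered here, and "the series" means these few. Any claim that something is new, unique, unknown or untested is made for them only; others in the source may bear on it.

Among the measured compounds shown here, in a functional assay on the whole organism (strain Wistar albino) for inhibition, with Rattus norvegicus as the target, read by paw edema, with stated times of 30 min and 1 h, at a dose of 20 mg/kg by the oral route (on this read-out higher numbers stand for more inhibition at the one dose given (going by the name of the read-out) and lower numbers for less inhibition), compound 3 `CC(C)Cc1ccc(C(C)c2nnc3sc(-c4ccc([N+](=O)[O-])cc4Cl)nn23)cc1` gives 4%, the lowest of the three numbers measured so far. Compound 1 `CCCc1nn2c(C(C)c3ccc(CC(C)C)cc3)nnc2s1` gives 15%, and compound 2 `CC(C)Cc1ccc(C(C)c2nnc3sc(-c4ccccc4Cl)nn23)cc1` gives 43%. The nitro group arrived with a number 39 percentage points lower from compound 2 to compound 3 (beyond the scatter), the aryl ring with a number 28 percentage points higher from compound 1 to compound 2 (beyond the scatter), and the two together with a number 11 percentage points lower from compound 1 to compound 3 (beyond the scatter). Compound 4 `CC(C)Cc1ccc(C(C)c2nnc3sc(-c4ccco4)nn23)cc1` carries furan-2-yl in place of 2-chloro-4-nitrophenyl on an aromatic carbon. Because a number 39 percentage points lower from compound 2 to compound 3 (beyond the scatter) went with the nitro group, and a number 28 percentage points higher from compound 1 to compound 2 (beyond the scatter) went with an aromatic ring in this position, a rise is expected for compound 4, namely a number 26 percentage points higher from compound 3 to compound 4 (beyond the scatter). The expected number for compound 4 is therefore 30%, with a range from 12% to 48%.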

Compound 4, a percentage reported as inhibition, in the whole organism at one dose (the size of the read-out at that dose, not a potency): 18%
Compound 4: middle estimate off by 12 percentage points, on the high side; low and high end bracket the measured number.
By their numbers in this assay, from the lowest: compound 3; then compounds 1 and 4 (each within the scatter of the next); then compound 2.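

In this assay, furan-2-yl in place of 2-chloro-4-nitrophenyl gives a number 14 percentage points higher from compound 3 to compound 4 (beyond the scatter) and so recovers only part of the drop seen with the nitro group. Against the chlorinated ring, furan-2-yl gives a number 25 percentage points lower from compound 2 to compound 4 (beyond the scatter) at this position, and against the plain chain it gives a number 3 percentage points higher from compound 1 to compound 4 (within the scatter) so an aromatic ring here does not by itself bring a high number. Nothing available explains why these rings differ.

Still open, from the compounds shown here alone, is whether a plain phenyl ring would hold the number of compound 2, and whether an amine on that ring or a longer chain in place of propyl would raise it.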